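Cyclotoxicity notes: nitro for acetamido, two cores

The source may report more compounds than this note shows. Statements on the series, on what has been measured and on what is new or still open speak of the compounds shown alone.

Measured so far:
compound 1 `Cn1c(-c2ccc([N+](=O)[O-])cc2)nc2cc(C(F)(F)F)ccc21`: >= 100000 nM
compound 2 `CC(=O)Nc1ccc(-c2nc3cc(C(F)(F)F)ccc3n2C)cc1`: 15000 nM
compound 3 `CC(=O)Nc1ccc(-c2nc3cc(C(F)(F)F)ccc3n2C2CCCCC2)cc1`: 24000 nM

In an ADME assay on MT4 cells (Homo sapiens) for cytotoxicity, read by MTT assay, with a stated time of 96 h (a higher number here means that more compound is tolerated, a lower number that less compound is tolerated), compound 1 gives >= 100000 nM, which is a limit of the assay and not a number. Compound 2 gives 15000 nM and compound 3 gives 24000 nM; their step of a 1.6-fold higher number from compound 2 to compound 3 (0.20 log units; within the scatter) follows the change (cyclohexyl in place of methyl on an aromatic nitrogen), which is how the two cores differ.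

The change nitro in place of acetamido on an aromatic carbon made the step of an at least 6.6-fold higher number from compound 2 to compound 1 (0.82 log units; beyond the scatter). Compound 4 `O=[N+]([O-])c1ccc(-c2nc3cc(C(F)(F)F)ccc3n2C2CCCCC2)cc1` carries the same change on the core of compound 3: nitro in place of acetamido on an aromatic carbon, with the place described in identical words.

For compound 4 a step of a 5.0-fold higher number from compound 3 to compound 4 (0.70 log units; beyond the scatter) is expected, resting on the step of an at least 6.6-fold higher number from compound 2 to compound 1 (0.82 log units; beyond the scatter) seen on the other core. Compound 4 is thus estimated at 120000 nM, most likely reported only as a limit.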

Compound 4, half-maximal cytotoxic concentration: 49000 nM
For compound 4 the middle estimate is 2.4-fold (0.39 log units) above the measured one; measured number outside the range, below it.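

Notes on carrying the change: In this assay nitro in place of acetamido gives a 2.0-fold higher number from compound 3 to compound 4 (0.31 log units; beyond the scatter) so the direction carries from one core to the other, but the size of the step does not: the same change on two cores in this assay, an at least 6.6-fold higher number (0.82 log units; beyond the scatter) from compound 2 to compound 1 and a 2.0-fold higher number (0.31 log units; beyond the scatter) from compound 3 to compound 4, at least 3.2-fold (0.51 log units) apart, beyond the scatter of two such steps

Cyclohexyl in place of methyl, read on the nitro pair, gives an at least 2.0-fold lower number from compound 1 to compound 4 (0.30 log units; that floor lies within the scatter) and does not match the step on the acetamido pair: the same change on two cores in this assay, a 1.6-fold higher number (0.20 log units; within the scatter) from compound 2 to compound 3 and an at least 2.0-fold lower number (0.30 log units; that floor lies within the scatter) from compound 1 to compound 4, at least 3.2-fold (0.51 log units) apart, beyond the scatter of two such steps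

Compound 1 stands at a limit, so both comparisons give only a floor and the full size of the gaps is not shown: the limit of >= 100000 nM in this assay, at which 1 of the 4 values shown sits.

From the compounds shown here alone, whether an amine or a carboxylic acid in place of nitro would fall in the same order remains open. So does the effect of a longer chain in place of cyclohexyl on the aromatic nitrogen.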